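This account rests on a few compounds, and the source may have more. Where it says the series, first, only, none or still open, it means among the compounds named here.

Two compounds of this series carry numbers in an in vitro functional assay on cells for agonist activity at Bombesin receptor subtype-3 (Mus musculus), read by luminescence and calcium flux; on this read-out higher numbers stand for an effect only at larger amounts of compound and lower numbers for an effect already at smaller amounts. Compound 1 `CCCCc1cnc(C(CCCO)Cc2ccc(-c3ccccc3C(=O)O)cc2)[nH]1` gives 238 nM in this assay. Compound 2 `O=C(O)c1ccccc1-c1ccc(CCc2ncc(CC3CCC3)[nH]2)cc1` gives 7.1 nM in this assay, the lowest of the two numbers shown; the gap up to compound 1 is beyond the scatter. Among the compounds with values here, no pair of measured compounds differs in only one place, so no measured step is available to carry forward. Compound 3 `O=C(O)c1ccccc1-c1ccc(CCc2ncc(CC3CCCCC3)[nH]2)cc1` differs from compound 2 in one place: cyclohexyl in place of cyclobutyl on a saturated chain carbon bound to an aromatic carbon. Cut one bond further out, the same difference reads cyclobutylmethyl to cyclohexylmethyl. Nothing measured here tells how this change moves the number in this assay; the expected step is therefore taken as none beyond the scatter, a 1.1-fold higher number from compound 2 to compound 3 (0.05 log units; within the scatter). Compound 3 is thus expected to give 8 nM in this assay, with a range from 2.5 nM to 30 nM to cover the uncertainty.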

Compound 3, half-maximal effective concentration: 7.3 nM
Compound 3: middle estimate off by 1.1-fold (0.04 log units), on the high side, within the range that was stated.
By their numbers in this assay, from the lowest: compounds 2 and 3 (each within the scatter of the next); then compound 1.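

Cyclohexyl in place of cyclobutyl on a saturated chain carbon bound to an aromatic carbon gives, in this assay, a 1.0-fold higher number from compound 2 to compound 3 (0.01 log units; within the scatter). Within the data shown here, this is the first one-place step, and it shows that at this position the four-membered and six-membered carbon rings cannot be told apart on this read-out, which the earlier pair, differing in more than one place, could not show. Nothing available explains this outcome.

Still open, from the compounds shown here alone, is whether the same holds for a phenyl ring, a piperidine ring bearing a basic amine, or a longer chain ending in the cyclohexyl ring at this position. Also open, going by these compounds, is whether a tetrazole in place of the carboxylic acid would keep the number in this range.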